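From Triazole to Carbamoylmethyl: An Expected Step

The source may hold more compounds than are shown below. What is called first, only, known or untested is meant among the compounds shown, and "the series" means these compounds.

Measured compounds:
compound 1 `CC(C)C(O)(C(=O)O)c1ccc(-c2ccc3ccccc3c2)[nH]c1=O`: 544 nM
compound 2 `CC(C)C(c1nnc[nH]1)c1ccc(-c2ccc3cccc(F)c3c2)[nH]c1=O`: 12 nM

Of the compounds shown here, two have been measured in an assay on CHO cells for displacement of a labelled ligand from prostaglandin E2 receptor EP3 subtype (Homo sapiens), read by radioligand binding; a higher number here means a weaker inhibitor, a lower number a stronger inhibitor. Compound 1 gives 544 nM, while compound 2 gives 12 nM, the lower of the two numbers; the gap between them lies well beyond the scatter of repeated measurements, so compound 2 stands as the stronger inhibitor of the pair. Among the compounds with values here, the two structures differ in several places at once, so no single-point step between them can be drawn.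

Compound 3 `CC(C)C(CC(N)=O)c1ccc(-c2ccc3cccc(F)c3c2)[nH]c1=O` is the next compound, and it differs from compound 2 in one place only: carbamoylmethyl in place of 4H-1,2,4-triazol-3-yl on a saturated chain carbon bound to an aromatic carbon and a saturated chain carbon. Within the data shown here, no measured pair shows this change, so its effect must be guessed. A loss in potency is expected, with the step in this assay from a 17-fold higher number from compound 2 to compound 3 (1.22 log units; beyond the scatter) likely beyond the scatter, though its size is uncertain. Compound 3 is therefore estimated at 200 nM, within a range from 40 nM to 1500 nM.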

Compound 3, inhibition constant: 5 nM
Estimate against measurement, compound 3: 40-fold (1.60 log units) above; the whole stated range lies above it.
By their numbers in this assay, from the lowest: compound 3; then compound 2; then compound 1.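

In this assay, placing carbamoylmethyl in place of 4H-1,2,4-triazol-3-yl on a saturated chain carbon bound to an aromatic carbon and a saturated chain carbon gives a 2.4-fold lower number from compound 2 to compound 3 (0.38 log units; beyond the scatter), a modest gain in potency. This position therefore does not depend on a five-membered aromatic ring in this pair: the open carbamoylmethyl, with no ring, does at least as well, while the hydrogen-bond donor count stays at 1 and the acceptor count falls from 2 to 1. Nothing at hand explains why the step runs in this direction.

What the compounds shown leave open is whether the amide itself carries this result, or whether a nitrile, a primary amine, an N,N-dimethylamide or a longer chain ending in the same amide would serve equally well on this carbon. On these data alone, they also show this change on one background only, so whether the same small gain would appear on another core remains unknown.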